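The source may hold more compounds than are shown below. What is called first, only, known or untested is meant among the compounds shown, and "the series" means these compounds.

Compound 1 `COc1ccc(C(=O)Nc2cccc(-c3oc4cc(-c5ccc(F)cc5)ccc4c(=O)c3O)c2)cc1`: 8420 nM.
Compound 2 `O=C(Nc1cccc(-c2oc3cc(-c4ccc(F)cc4)ccc3c(=O)c2O)c1)c1ccc(Br)cc1F`: > 100000 nM (a limit, not a number).

In a functional assay on HepG2 cells (Homo sapiens) for antiproliferative activity, read by CCK-8 assay, with a stated time of 72 h (on this read-out lower numbers stand for stronger inhibition and higher numbers for weaker inhibition), compound 1 gives 8420 nM, the only number shown here. For compound 2 the assay returned only a limit, > 100000 nM. Compound 3 `O=C(Nc1cccc(-c2oc3cc(-c4ccc(F)cc4)ccc3c(=O)c2O)c1)c1ccc(-c2ccccc2)cc1` is not yet measured; it differs from compound 1 by phenyl in place of methoxy on an aromatic carbon. Within the data shown here, the only known step, an at least 11-fold higher number from compound 1 to compound 2 (1.07 log units; beyond the scatter), also replaced the group on the carbonyl carbon and cost much inhibition. A change at that same spot therefore makes some weakening plausible, though a phenyl is a different kind of group, so the expectation is loose. Compound 3 is expected to give 15000 nM, between 4000 nM and 60000 nM, an expected step of a 1.8-fold higher number from compound 1 to compound 3 (0.25 log units; within the scatter).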

Compound 3, half-maximal inhibitory concentration: 88500 nM
Beside the measured number, compound 3's estimate is 5.9-fold (0.77 log units) below it; measured number outside the range, above it.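

In this assay, phenyl in place of methoxy gives an 11-fold higher number from compound 1 to compound 3 (1.02 log units; beyond the scatter), so the large loss seen with compound 2 is not tied to a ring carrying bromine and fluorine. The step of an at least 1.1-fold lower number from compound 2 to compound 3 (0.05 log units; that floor lies within the scatter) does not rank these two replacements. Compound 2 has only a limit, not a number: the limit of > 100000 nM in this assay, at which 1 of the 3 values shown sits.

Going by these compounds, whether any replacement can match or beat methoxy remains open. A hydroxyl, an ethoxy or a dimethylamino group at this spot would show whether inhibition depends on a small group with an oxygen or nitrogen attached to the ring.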